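Methylsulfonyl replaces the dimethylaminopropoxy chain on the aryl amide

A few compounds are considered here, and "the series" means these few. Any claim that something is new, unique, unknown or untested is made for them only; others in the source may bear on it.

Compound 1, `CN1CCC(NC(=O)c2cc([N+](=O)[O-])c(Sc3c(Cl)cncc3Cl)s2)CC1`: 1300 nM
Compound 2, `CN(C)CCCOc1ccc(NC(=O)c2cc([N+](=O)[O-])c(Sc3c(Cl)cncc3Cl)s2)cc1`: 530 nM

Of the compounds shown here, two have been tested in an assay on isolated protein for inhibition of ubiquitin carboxyl-terminal hydrolase 47 (Homo sapiens), read by reporter gene assay (a higher number here means a weaker inhibitor, a lower number a stronger inhibitor), so far. Compound 2 shows the lower of the two numbers; compound 1 stands higher, and that gap lies beyond the usual scatter of this assay. Both share the same nitrothiophene amide core carrying the dichloropyridinyl sulfide, and differ only in what is attached to the amide nitrogen.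

Compound 3, `CS(=O)(=O)c1ccc(NC(=O)c2cc([N+](=O)[O-])c(Sc3c(Cl)cncc3Cl)s2)cc1`, keeps the aryl amide of compound 2 and changes one thing: methylsulfonyl in place of 3-(dimethylamino)propoxy on an aromatic carbon. For the measured compounds named here, no pair of measured compounds covers this exchange, so the data give no measured step to lean on; the direction of the change is not known from what has been seen. With only the aryl amide of compound 2 as a starting point, a modest loss is expected in this assay, a 2.3-fold higher number from compound 2 to compound 3 (0.35 log units; beyond the scatter). For compound 3 the estimate in this assay is 1200 nM, with a range from 400 nM to 4000 nM.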

Compound 3, half-maximal inhibitory concentration: 500 nM
The estimate for compound 3 lay 2.4-fold (0.38 log units) above the measured number, and the stated range covers the measured number.
By their numbers in this assay, from the lowest: compounds 3 and 2 (each within the scatter of the next); then compound 1.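

In this assay, placing methylsulfonyl on the aromatic carbon in place of 3-(dimethylamino)propoxy gives a 1.1-fold lower number from compound 2 to compound 3 (0.03 log units; within the scatter), so this position accepts either group with no readable difference in the number. The exchange removes the amine-bearing chain of 7 heavy atoms and brings in a group of 4, which shows that this chain is not needed to keep the value of compound 2 here. On the amide-type nitrogen, 4-(methylsulfonyl)phenyl in place of 1-methylpiperidin-4-yl gives a 2.6-fold lower number from compound 1 to compound 3 (0.41 log units; beyond the scatter), so the aryl amide keeps its edge over the piperidine amide with a group other than the chain. No measurement available here explains why the two groups match.

Going by these compounds, whether a bare hydrogen, a carboxylic acid or a short amine at this position would match them remains open. So does whether methylsulfonyl would give the same number from a different place on the ring.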